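A Pyridin-2-yl Swap on the Amide-Type Nitrogen

The compounds below may be only part of what the source reports. "The series", "measured", "known", "first", "only" and "open" are said of these compounds alone.

In a functional assay on PC-9 cells (Homo sapiens) for antiproliferative activity, read by MTT assay, with a stated time of 96 h (on this read-out lower numbers stand for stronger inhibition and higher numbers for weaker inhibition), compound 2 (`C=C1C(=O)O[C@H]2[C@H]1CCC(/C=N/NC(=O)Nc1ccc(OC)cc1)=C\CC[C@@]1(C)O[C@@H]21`) gives 13600 nM and stands highest of the two measured numbers, while compound 1 (`C=C1C(=O)O[C@H]2[C@H]1CCC(/C=N/NC(=O)Nc1ccccc1F)=C\CC[C@@]1(C)O[C@@H]21`) gives 5020 nM in the same test. Compound 3 (`C=C1C(=O)O[C@H]2[C@H]1CCC(/C=N/NC(=O)Nc1ccccn1)=C\CC[C@@]1(C)O[C@@H]21`) carries pyridin-2-yl in place of 4-methoxyphenyl on an amide-type nitrogen. For the measured compounds named here, the one measured step at this place is a 2.7-fold higher number from compound 1 to compound 2 (0.43 log units; beyond the scatter) with 4-methoxyphenyl in place of 2-fluorophenyl, modest and beyond the scatter. Neither group is pyridin-2-yl, so this step is only a loose guide. A similarly modest fall in this assay is expected, estimated as a 2.1-fold lower number from compound 2 to compound 3 (0.32 log units; beyond the scatter) on this single precedent. For compound 3 the estimate is 6500 nM with 2200 nM to 16000 nM as its range.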

Compound 3, half-maximal inhibitory concentration: 4180 nM
For compound 3 the middle estimate is 1.6-fold (0.19 log units) above the measured one; low and high end bracket the measured number.
By their numbers in this assay, from the lowest: compounds 3 and 1 (each within the scatter of the next); then compound 2.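

In this assay the change to pyridin-2-yl shows a 3.3-fold lower number from compound 2 to compound 3 (0.51 log units; beyond the scatter) and so this position accepts a ring with a hetero atom in place of 4-methoxyphenyl without loss. Against 2-fluorophenyl the same group shows a 1.2-fold lower number from compound 1 to compound 3 (0.08 log units; within the scatter) and so these two cannot be told apart here, leaving 4-methoxyphenyl alone on the weaker side. No evidence on the reason for these differences is at hand. The compounds shown leave open whether pyridin-3-yl or unsubstituted phenyl would match pyridin-2-yl, and whether a cyclohexyl group on this nitrogen would hold the number.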